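The source may hold more compounds than are shown below. What is called first, only, known or untested is meant among the compounds shown, and "the series" means these compounds.

Among the compounds with values here, compound 2 `CN(C)CCn1cnnc1-c1cc(Oc2ccc(NC(=O)N/N=C/c3ccc(O)cc3)cc2F)ccn1` is the only compound here with a plain number in a functional assay on A549 cells (Homo sapiens) for cytotoxicity, read by MTT assay, with a stated time of 72 h; a lower number here means a stronger inhibitor, a higher number a weaker inhibitor: in this assay compound 2 gives 3560 nM. Compound 1 `COc1cc(/C=N/NC(=O)Nc2ccc(Oc3ccnc(-c4nncn4CCN(C)C)c3)c(F)c2)cc(OC)c1OC` gives only a limit in this assay, > 100000 nM. Within the data shown here, the single measured step, an at least 28-fold lower number from compound 1 to compound 2 (1.44 log units; beyond the scatter), goes with the exchange of 3,4,5-trimethoxyphenyl for 4-hydroxyphenyl on a carbon with a double bond to nitrogen, and its size is set by the limit of > 100000 nM in this assay, at which 1 of the 2 values shown sits. Compound 3 `COc1ccc(/C=N/NC(=O)Nc2ccc(Oc3ccnc(-c4nncn4CCN(C)C)c3)c(F)c2)cc1O` carries 3-hydroxy-4-methoxyphenyl in place of 4-hydroxyphenyl on a carbon with a double bond to nitrogen. This change brings one methoxy group back, moving part of the way toward compound 1, whose limit shows a far weaker inhibitor. A shift toward a higher number is therefore expected, though much smaller than the measured step, and the step is estimated as a 2.2-fold higher number from compound 2 to compound 3 (0.35 log units; beyond the scatter). Compound 3 is estimated at 8000 nM, within 2500 nM to 30000 nM.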

Compound 3, half-maximal inhibitory concentration: > 100000 nM
Compound 3 was reported as a limit (the forecaster's own chance of this, stated with the estimate: 5%); at least 12-fold (1.09 log units) between middle value and limit.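

In this assay, the ring on the carbon with a double bond to nitrogen proves highly sensitive: exchanging 4-hydroxyphenyl for 3-hydroxy-4-methoxyphenyl gives an at least 28-fold higher number from compound 2 to compound 3 (1.44 log units; beyond the scatter). The earlier step replaced a ring carrying three methoxy groups, whereas this one shows that a ring with a single methoxy group and a hydroxy group of its own can also fall out of the measurable range, so a hydroxy group on the ring does not by itself preserve activity. The true size of this step is unknown, and the step between compound 1 and compound 3 cannot be read, because the values of both compounds are limits: the limit of > 100000 nM in this assay, at which 2 of the 3 values shown sit.

As far as these compounds go, it remains open whether the added methoxy group or the changed place of the hydroxy group matters more. A 3-hydroxyphenyl or a 4-methoxyphenyl group on the same carbon would separate these two changes, and a 4-aminophenyl group would test whether the hydroxy group can be replaced by an amine.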